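A Methyl Added to Compound 1: What to Expect

The source may hold more compounds than are shown below. What is called first, only, known or untested is meant among the compounds shown, and "the series" means these compounds.

In a functional assay on the whole organism (strain Swiss albino) for inhibition, with Mus musculus as the target, in the writhing test, with stated times of 30 min and 15 min, at a dose of 50 mg/kg by the oral route (a lower number here means less inhibition, a higher number more inhibition at the dose given (going by the name of the read-out)), three compounds have been measured so far:
compound 1 `O=C1N/C(=N/c2ccccc2)S/C1=C\c1ccccn1` gives 29.2%
compound 2 `O=C1N/C(=N\Nc2ccccc2)S/C1=C\c1ccccn1` gives 46.2%
compound 3 `O=C1N/C(=N\c2ccccc2[N+](=O)[O-])S/C1=C/c1ccccn1` gives 36.7%

Compound 1 has the lowest of these three numbers. Its nearest neighbour is compound 3, whose value lies within the scatter of it, so the two cannot be ordered. Compound 2 lies furthest away, beyond the scatter, and so does show more inhibition than compound 1.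

Compound 4 `Cc1ccccc1/N=C1/NC(=O)/C(=C/c2ccccn2)S1` differs from compound 1 by methyl in place of hydrogen on an aromatic carbon. Within the data shown here, no measured pair shows a change of this kind, so nothing in the data sets its size. The small group entering is expected to leave the number within the scatter of compound 1, so the step of a number 3.8 percentage points higher from compound 1 to compound 4 (within the scatter) is estimated to be none beyond the scatter. Compound 4 is estimated at 33%, in the range 18% to 48%.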

Compound 4, a percentage reported as inhibition, in the whole organism at one dose (the size of the read-out at that dose, not a potency): 43.6%
Estimate against measurement, compound 4: 10.6 percentage points below, within the range that was stated.
By their numbers in this assay, from the lowest: compounds 1, 3, 4 and 2 (each within the scatter of the next, the first and the last beyond it).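

In this assay, among these compounds, the change from phenyl to 2-methylphenyl gives a number 14.4 percentage points higher from compound 1 to compound 4 (beyond the scatter) and is the first single change that can be read. It shows that this aromatic carbon, ortho to a large group, is a place where methyl in place of hydrogen can move the read-out beyond the scatter. Nothing measured here explains the step.

On these data alone, whether a chlorine atom, a methoxy group or a longer chain on this carbon would give a similar step stays open. So does whether methyl on another carbon of this ring would.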